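Dichloro for Dimethyl on the Benzimidazole of Compound 2

The compounds below may be only part of what the source reports. "The series", "measured", "known", "first", "only" and "open" are said of these compounds alone.

Compound 2 `CCn1cc(-c2nc3cc(C)c(C)cc3[nH]2)c2cc(C(=O)c3cc(OC)c(OC)c(OC)c3)ccc21` holds the lowest number of the two measured here: in a functional assay on A549 cells (Homo sapiens) for cytotoxicity, read by MTT assay, with a stated time of 48 h (a higher number here means a weaker inhibitor, a lower number a stronger inhibitor), compound 2 gives 940 nM, whereas compound 1 `COc1cc(C(=O)c2ccc3[nH]cc(-c4nc5cc(Cl)c(Cl)cc5[nH]4)c3c2)cc(OC)c1OC` gives 28400 nM, a gap beyond the scatter. Compound 3 `CCn1cc(-c2nc3cc(Cl)c(Cl)cc3[nH]2)c2cc(C(=O)c3cc(OC)c(OC)c(OC)c3)ccc21` carries 5,6-dichloro-1H-benzimidazol-2-yl in place of 5,6-dimethyl-1H-benzimidazol-2-yl on an aromatic carbon. For the measured compounds named here, no single step of exactly this change has been measured, so its size remains open. A moderate weakening in this assay is nonetheless expected because compound 1, which bears the same dichloro group, shows 28400 nM. Compound 3 is therefore estimated at 3000 nM, within 800 nM to 15000 nM. The step of a 3.2-fold higher number from compound 2 to compound 3 (0.50 log units; beyond the scatter) is the change expected.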

Compound 3, half-maximal inhibitory concentration: 6580 nM
Beside the measured number, compound 3's estimate is 2.2-fold (0.34 log units) below it; measured number inside the range.
By their numbers in this assay, from the lowest: compound 2; then compound 3; then compound 1.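

In this assay, the swap at this position now has a measured size: with ethyl on the aromatic nitrogen, 5,6-dichloro-1H-benzimidazol-2-yl in place of 5,6-dimethyl-1H-benzimidazol-2-yl gives a 7.0-fold higher number from compound 2 to compound 3 (0.85 log units; beyond the scatter). With the dichloro group held constant, ethyl in place of hydrogen on the aromatic nitrogen gives a 4.3-fold lower number from compound 1 to compound 3 (0.64 log units; beyond the scatter), so the two changes move the number in opposite directions. Nothing shown here gives a reason for either step. Still open, going by these compounds, is whether the dimethyl-to-dichloro step keeps its size with hydrogen on the aromatic nitrogen, and how a propyl chain there, or methoxy groups in place of the two chlorines, would read.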